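The compounds below may be only part of what the source reports. "The series", "measured", "known", "first", "only" and "open" are said of these compounds alone.

Compound 1 `CCCCOc1ccc(C(=O)NNC(=O)c2cccc(NS(=O)(=O)c3cnc(O)nc3O)c2)cc1` is the starting point of this small set. In a functional assay on SGC-7901 cells (Homo sapiens) for antiproliferative activity, read by MTT assay, with a stated time of 24 h (on this read-out lower numbers stand for stronger inhibition and higher numbers for weaker inhibition), compound 1 gives 7370 nM. Compound 2 `Cc1ccccc1C(=O)NNC(=O)c1cccc(NS(=O)(=O)c2cnc(O)nc2O)c1` carries the change (2-methylphenyl in place of 4-butoxyphenyl on a carbonyl carbon). In this assay compound 2 reaches only a limit, > 20000 nM. That limit is the one described by the limit of > 20000 nM in this assay, at which 1 of the 3 values shown sits, so the step of an at least 2.7-fold higher number from compound 1 to compound 2 (0.43 log units; beyond the scatter) can only be given as a lower bound.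

Compound 3 `CCCCOc1ccc(C(=O)NNC(=O)c2ccccc2NS(=O)(=O)c2cnc(O)nc2O)cc1` has the same atoms as compound 1 joined differently; the difference between the two cores is not broken down here. In this assay compound 3 gives 6890 nM, a number within the scatter of compound 1.

Compound 4 `Cc1ccccc1C(=O)NNC(=O)c1ccccc1NS(=O)(=O)c1cnc(O)nc1O` stands to compound 3 as compound 2 stands to compound 1, by the change (2-methylphenyl in place of 4-butoxyphenyl on a carbonyl carbon), made at a place described in the same words, so it is the same change. Since compound 3 starts from 6890 nM, the step of a 3.2-fold higher number from compound 3 to compound 4 (0.50 log units; beyond the scatter) expected for this change would leave compound 4 as a weak inhibitor. Compound 4 is therefore estimated at 22000 nM, with a fair chance that only a limit is reported.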

Compound 4, half-maximal inhibitory concentration: 13000 nM
Beside the measured number, compound 4's estimate is 1.7-fold (0.23 log units) above it; low and high end bracket the measured number.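

In this assay the placing of 2-methylphenyl where 4-butoxyphenyl stood, on the core of compound 3, gives a 1.9-fold higher number from compound 3 to compound 4 (0.28 log units; within the scatter) and so stays inside the usual scatter on this core. Set beside the step on the core of compound 1, the two readings compare as follows: the same change on two cores in this assay, an at least 2.7-fold higher number (0.43 log units; beyond the scatter) from compound 1 to compound 2 and a 1.9-fold higher number (0.28 log units; within the scatter) from compound 3 to compound 4; the limit leaves it open whether they differ. For the compounds shown here, this shows that the change goes beyond the scatter on only one of the two cores, and it does not show either that the two cores respond to it differently or that they respond alike.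

The compounds shown leave open whether other groups on this carbonyl carbon, such as a longer alkoxy chain, an amine or a carboxylic acid, would give matching steps on the two cores. With only 4-butoxyphenyl and 2-methylphenyl compared, they also leave open the real size of the step to compound 2, whose reading is only a limit: the limit of > 20000 nM in this assay, at which 1 of the 4 values shown sits.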